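A Ring Returns to the Side Chain

A few compounds are considered here, and "the series" means these few. Any claim that something is new, unique, unknown or untested is made for them only; others in the source may bear on it.

In an ADME assay on MT4 cells (Homo sapiens) for cytotoxicity (a higher number here means that more compound is tolerated, a lower number that less compound is tolerated), compound 1 `FC(F)(F)c1cccc(NC(=S)Nc2ccc(Cl)cc2)c1` gives 6800 nM and compound 2 `C=C(C)CNC(=S)Nc1cccc(C(F)(F)F)c1` gives 43000 nM as the higher of the two numbers. Compound 3 `FC(F)(F)c1cccc(NC(=S)NCc2ccco2)c1` keeps the shared core and differs from compound 2 at one place: furan-2-yl in place of 1-methylethenyl on a saturated chain carbon bound to an amide-type nitrogen describes the change. For the measured compounds named here, the one measured step bearing on this is a 6.3-fold higher number from compound 1 to compound 2 (0.80 log units; beyond the scatter) when 2-methylprop-2-en-1-yl replaces 4-chlorophenyl and it is modest, so with a ring returning a small drop is expected, not clearly beyond the scatter. The estimated change is a 1.8-fold lower number from compound 2 to compound 3 (0.25 log units; within the scatter) in this reading. Compound 3 is expected at 24000 nM with an estimated range from 10000 nM to 60000 nM in this assay.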

Compound 3, half-maximal cytotoxic concentration: 43000 nM
Compound 3: middle estimate off by 1.8-fold (0.25 log units), on the low side; low and high end bracket the measured number.
By their numbers in this assay, from the lowest: compound 1; then compounds 2 and 3 (each within the scatter of the next).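

In this assay, putting furan-2-yl in place of 1-methylethenyl gives no change at the digits printed from compound 2 to compound 3 (within the scatter) here, so a ring on this saturated chain carbon does not by itself bring the number down towards that of compound 1. Placing (furan-2-yl)methyl instead of 4-chlorophenyl on the amide-type nitrogen gives a 6.3-fold higher number from compound 1 to compound 3 (0.80 log units; beyond the scatter) in this assay, the same gap that the open-chain group showed. No measured evidence accounts for either result.

A benzyl group on this nitrogen could separate the effect of the ring's type from that of the saturated chain carbon. A chain ending in an amine or a carboxylic acid remains untested among these compounds.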